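Sulfonyl in place of carbonyl on the amine nitrogen

The source may report more compounds than this note shows. Statements on the series, on what has been measured and on what is new or still open speak of the compounds shown alone.

Measured compounds:
compound 1 `CCCCCCCCCCCCCCCCCCNC(=O)[C@@H](NC(=O)c1cc2ccccc2o1)[C@@H](C)O`: 126000 nM
compound 2 `C/C=C/C=C/C(=O)N[C@H](C(=O)NCCCCCCCCCCCCCCCCCC)[C@@H](C)O`: 79600 nM

In a functional assay on MCF7 cells (Homo sapiens) for cytotoxicity, read by MTT assay, with a stated time of 48 h (on this read-out lower numbers stand for stronger inhibition and higher numbers for weaker inhibition), compound 1 gives 126000 nM, and compound 2 gives 79600 nM. These two numbers sit within the scatter of each other, as the step of a 1.6-fold lower number from compound 1 to compound 2 (0.20 log units; within the scatter) shows, so neither compound can be called more active than the other on the evidence at hand.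

Compound 3 `CCCCCCCCCCCCCCCCCCNC(=O)[C@@H](NS(=O)(=O)c1ccc(C)cc1)[C@@H](C)O` is the next step from compound 2: (4-methylphenyl)sulfonyl in place of (penta-1,3-dien-1-yl)carbonyl on an amine nitrogen. Among the measured compounds shown here, the only measured step changes the group on the carbonyl carbon while keeping the carbonyl itself; no measured pair exchanges a carbonyl for a sulfonyl on this nitrogen. That step was within the scatter, and it gives no guide to the direction of the new change. For compound 3 the expected outcome is therefore a number close to that of compound 2, with a wide range on both sides, an estimated step of a 1.1-fold higher number from compound 2 to compound 3 (0.05 log units; within the scatter). The estimate for compound 3 in this assay is 90000 nM, between 25000 nM and 320000 nM.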

Compound 3, half-maximal inhibitory concentration: 60100 nM
For compound 3 the middle estimate is 1.5-fold (0.18 log units) above the measured one; measured number inside the range.
By their numbers in this assay, from the lowest: compounds 3, 2 and 1 (each within the scatter of the next, the first and the last beyond it).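

Putting a sulfonyl in place of the carbonyl on the amine nitrogen, a swap the earlier pair did not cover, does not clearly change the result in this assay, with a 1.3-fold lower number from compound 2 to compound 3 (0.12 log units; within the scatter). Set against the benzofuran compound, the same kind of swap gives a 2.1-fold lower number from compound 1 to compound 3 (0.32 log units; beyond the scatter), the first step in this set to pass the scatter, though only modestly, so (4-methylphenyl)sulfonyl can be told apart from (1-benzofuran-2-yl)carbonyl on this nitrogen but not from (penta-1,3-dien-1-yl)carbonyl. Nothing available explains this small difference.

From the compounds shown here alone, whether a simple methylsulfonyl or a free amine on this nitrogen would shift the number further remains open. So does the effect of a shorter chain in place of the long chain shared by all three compounds.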